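Fluoro for nitro on a shared benzoxazole-free core: an estimate

A few compounds are considered here, and "the series" means these few. Any claim that something is new, unique, unknown or untested is made for them only; others in the source may bear on it.

Measured so far:
compound 1, `CN1CCN(c2nc3cc([N+](=O)[O-])ccc3o2)CC1`: 0.52
compound 2, `COc1cc(Cl)cc2nc(N3CCN(C)CC3)oc12`: 0.62
compound 3, `COc1cc(C)cc2nc(N3CCN(C)CC3)oc12`: 0.56

In an assay on ileum (strain Hartley) with 5-hydroxytryptamine receptor 3A (Cavia porcellus) as the target (a higher number here means a larger maximal response, a lower number a smaller maximal response), compound 1 gives 0.52 and stands at the lower end of the three numbers, but only within the scatter of the others: compound 3 gives 0.56 and compound 2 gives 0.62, and neither gap exceeds what repeated measurements usually show. Within the data shown here, the single step recorded between measured compounds, a number 0.060 lower from compound 2 to compound 3 (within the scatter), also stays within the scatter.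

Compound 4, `CN1CCN(c2nc3cc(F)ccc3o2)CC1`, has not been measured. It differs from compound 1 as follows: fluoro in place of nitro on an aromatic carbon. Among the measured compounds shown here, no measured step touches this group, so the exchange of chloro for methyl in a number 0.060 lower from compound 2 to compound 3 (within the scatter) is the only guide to how a change at this position of the shared core behaves, and it was small. Compound 4 is therefore expected to show no step beyond the scatter, no change at the digits printed from compound 1 to compound 4 (within the scatter). The estimated value of compound 4 in this assay is 0.52, with a range from 0.35 to 0.7.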

Compound 4, intrinsic activity: the largest response reached, as a fraction of the reference agonist's: 0.64
The estimate for compound 4 lay 0.12 below the measured number; the range from low to high includes it.
By their numbers in this assay, from the lowest: compounds 1, 3, 2 and 4 (each within the scatter of the next, the first and the last beyond it).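

In this assay, fluoro in place of nitro on this aromatic carbon gives a number 0.12 higher from compound 1 to compound 4 (beyond the scatter), so a single exchange at this place on the shared core can move the maximal response beyond the scatter. The earlier step, a number 0.060 lower from compound 2 to compound 3 (within the scatter), stayed within the scatter and showed no such shift for methyl in place of chloro. Nothing shown here bears on why the exchange of nitro for fluoro has this effect.

With one step at this place on the core of compound 1, the compounds shown cannot tell whether the higher number follows from the loss of nitro or from the arrival of fluoro. They also leave open how an amino group or a nitrile on the same carbon would compare with either.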